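This account rests on a few compounds, and the source may have more. Where it says the series, first, only, none or still open, it means among the compounds named here.

In a functional assay on HepG2 cells (Homo sapiens) for cytotoxicity, with a stated time of 72 h (a higher number here means that more compound is needed for the effect, a lower number that less compound is needed), compound 1 `C=C[C@@](C)(/C=C/c1ccc(OCc2ccccc2)cc1)CCC=C(C)C` gives > 52000 nM, which is a limit and not a number. Compound 2 `C=C[C@@](C)(/C=C/c1ccc(O)c(/C=C/C(=O)c2ccccc2)c1)CCC=C(C)C` gives > 52000 nM, again a limit. Compound 2 therefore has no number of its own, and the data so far hold only (the limit of > 52000 nM in this assay, at which 2 of the 2 values shown sit). Compound 3 `C=C[C@@](C)(/C=C/c1ccc(O)c(/C=C/C(=O)O)c1)CCC=C(C)C` carries hydroxy in place of phenyl on a carbonyl carbon, so that benzoyl becomes carboxy (hydroxy in place of phenyl on a carbonyl carbon). For the measured compounds named here, no measured step speaks directly to this change, so any expectation is tentative. In this assay no shift beyond the usual scatter is expected, in either direction, and the estimated step is a number no higher from compound 2 to compound 3 (the limit leaves the size open). Compound 3 will most likely also be reported only as a limit. As a number, the expected value for compound 3 is 52000 nM, with an estimated range from 26000 nM to 100000 nM.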

Compound 3, half-maximal effective concentration: > 52000 nM
Compound 3 ended at the assay's limit; the forecaster's own chance of this, stated with the estimate: 85%; the middle value lies on the limit itself.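

Compound 2 and compound 3 are each reported only as a limit in this assay, so no step can be read between them. The compounds shown leave open whether changing benzoyl to carboxy moves the value at all, and the data hold only one limit: the limit of > 52000 nM in this assay, at which 3 of the 3 values shown sit.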